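This account rests on a few compounds, and the source may have more. Where it says the series, first, only, none or still open, it means among the compounds named here.

Measured compounds:
compound 1, `CN(C)c1ccc(C(=O)N2CCC(NS(=O)(=O)c3cc(S(=O)(=O)c4ccccc4)ccc3C(F)(F)F)CC2)cc1`, 190 nM in an assay on U2OS cells for inhibition of secreted frizzled-related protein 1 (Homo sapiens), read by a luciferase reporter, with a stated time of 18 h; a lower number here means that less compound is needed, a higher number that more compound is needed for the effect;
compound 2, `O=C(c1ccc(Cl)nc1)N1CCC(NS(=O)(=O)c2cc(S(=O)(=O)c3ccccc3)ccc2C(F)(F)F)CC1`, 140 nM;
compound 3, `O=C(O)c1cccc(S(=O)(=O)N2CCC(NS(=O)(=O)c3cc(S(=O)(=O)c4ccccc4)ccc3C(F)(F)F)CC2)c1`, 190 nM.

All three numbers lie within the usual scatter of one another. Compound 3 is level with compound 1, and its furthest neighbour is compound 2, with a 1.4-fold higher number from compound 2 to compound 3 (0.13 log units; within the scatter). The other two steps, a 1.4-fold lower number from compound 1 to compound 2 (0.13 log units; within the scatter) and no change at the digits printed from compound 1 to compound 3 (within the scatter), are likewise within the scatter, although each exchanges the whole group on the ring nitrogen of the shared core.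

Compound 4, `N#Cc1cccc(S(=O)(=O)N2CCC(NS(=O)(=O)c3cc(S(=O)(=O)c4ccccc4)ccc3C(F)(F)F)CC2)c1`, differs from compound 3 by cyano in place of carboxy on an aromatic carbon. For the measured compounds named here, none of the measured steps touches this position: every one of them replaces the complete substituent on the ring nitrogen, and the largest of them still stays within the scatter. Going by the values given here, there is no measured step that bears directly on a change within the aryl group itself. On this footing, the expected step of no change at the digits printed from compound 3 to compound 4 (within the scatter) is none beyond the scatter. Compound 4 is therefore estimated at 190 nM, with a range from 80 nM to 450 nM.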

Compound 4, half-maximal effective concentration: 170 nM
Estimate against measurement, compound 4: 1.1-fold (0.05 log units) above; low and high end bracket the measured number.
By their numbers in this assay, from the lowest: compounds 2, 4, 1 and 3 (each within the scatter of the next).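

In this assay, cyano in place of carboxy on this aromatic carbon gives a 1.1-fold lower number from compound 3 to compound 4 (0.05 log units; within the scatter), the first step shown that alters the aryl group itself rather than replacing the whole group on the ring nitrogen, and the hydrogen-bond donor of the carboxy leaves without a change beyond the scatter. Compound 4 also stays level with the two carbonyl compounds, with a 1.2-fold higher number from compound 2 to compound 4 (0.08 log units; within the scatter) and a 1.1-fold lower number from compound 1 to compound 4 (0.05 log units; within the scatter), so this set of four shows no separation by the group on the ring nitrogen. Nothing available gives a reason for this result.

As far as these compounds go, it remains open whether an amine or a primary amide on this aromatic carbon would also stay within the scatter. From the compounds shown here alone, it is equally open whether cyano or carboxy would give the same number on another carbon of that ring.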